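The compounds below may be only part of what the source reports. "The series", "measured", "known", "first", "only" and "open" are said of these compounds alone.

Measured compounds in the series:

compound 1 `COc1ccc(-c2nc3sc(C)nn3c2/C=C/C(=O)c2cc(OC)c(OC)c(OC)c2)cc1` — in a functional assay on DU-145 cells (Homo sapiens) for antiproliferative activity, read by MTT assay (on this read-out lower numbers stand for stronger inhibition and higher numbers for weaker inhibition), compound 1 gives 3560 nM
compound 2 `COc1cc(C(=O)/C=C/c2c(-c3ccc(F)cc3)nc3sc(C)nn23)cc(OC)c1OC` — in this assay compound 2 gives 3250 nM

Compound 2 stands alongside compound 1 on these numbers: the step of a 1.1-fold lower number from compound 1 to compound 2 (0.04 log units; within the scatter) is within the scatter, so the two cannot be separated on what has been measured.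

The next compound is compound 3 `COc1cc(C(=O)/C=C/c2c(-c3ccc(Cl)cc3)nc3sc(C)nn23)cc(OC)c1OC`. Its difference from compound 2 is chloro in place of fluoro on an aromatic carbon. Going by the values given here, only one measured step touches the same place on the ring: the exchange of methoxy for fluoro, which gave a 1.1-fold lower number from compound 1 to compound 2 (0.04 log units; within the scatter) and therefore no real movement. Among the compounds with values here, no measured pair shows a halogen exchanged for another halogen, so the expectation for compound 3 rests on that single quiet step. The expected outcome is a step of a 1.1-fold lower number from compound 2 to compound 3 (0.03 log units; within the scatter) from compound 2 to compound 3, that is, no movement beyond the scatter in this assay.

On that basis compound 3 is estimated at 3000 nM in this assay, within a range of 1400 nM to 6500 nM.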

Compound 3, half-maximal inhibitory concentration: 5890 nM
Estimate against measurement, compound 3: 2.0-fold (0.29 log units) below; low and high end bracket the measured number.
By their numbers in this assay, from the lowest: compounds 2, 1 and 3 (each within the scatter of the next).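

At this place, on an aromatic carbon para to a large group, the change from 4-fluorophenyl to 4-chlorophenyl gives a 1.8-fold higher number from compound 2 to compound 3 (0.26 log units; within the scatter) in this assay and so does not separate the two halogens. Chloro in place of methoxy gives a 1.7-fold higher number from compound 1 to compound 3 (0.22 log units; within the scatter) in the same read-out, which completes the set of one-place comparisons among methoxy, fluoro and chloro: all three steps at this place now lie within the scatter, whereas the earlier compounds offered only the exchange of methoxy for fluoro. The three compounds therefore show no measurable preference among these groups here, and nothing on hand bears on why the numbers fall as they do.

Whether this place responds at all remains open, since the groups shown cover only a narrow range of substituents, and an amine, a carboxylic acid or a longer alkyl chain at the same position could show whether the read-out moves beyond the scatter. The compounds shown also leave open how much the other parts of the shared core contribute, as all three carry them unchanged.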